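The source may hold more compounds than are shown below. What is called first, only, known or untested is meant among the compounds shown, and "the series" means these compounds.

Working notes on the series. In a functional assay on HT-29 cells (Homo sapiens) for inhibition, read by CCK-8 assay, with a stated time of 24 h (on this read-out higher numbers stand for weaker inhibition and lower numbers for stronger inhibition), compound 3 `N#Cc1ccccc1-n1cc(-c2ccc(C=C3C(=O)Nc4ccc(F)cc43)cc2)nn1` gives only > 13900 nM, which is a limit and not a number; it is the limit of > 13900 nM in this assay, at which 1 of the 3 values shown sits.

Compound 4 `N#Cc1ccc(-n2cc(-c3ccc(C=C4C(=O)Nc5ccc(F)cc54)cc3)nn2)cc1` differs from compound 3 by 4-cyanophenyl in place of 2-cyanophenyl on an aromatic nitrogen, the same atoms joined differently. Among the compounds with values here, no measured pair isolates this change.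

Within the data shown here, the one measured step nearby is an at least 1.7-fold higher number from compound 2 to compound 3 (0.23 log units; that floor lies within the scatter), with cyano in place of hydrogen on an aromatic carbon. It rests on a limit and stays within the scatter. Compound 2 `O=C1Nc2ccc(F)cc2C1=Cc1ccc(-c2cn(-c3ccccc3)nn2)cc1` gives 8120 nM. Compound 1 `N#Cc1ccc(-n2cc(-c3ccc(C=C4C(=O)Nc5ccccc54)cc3)nn2)cc1` carries the same 4-cyanophenyl on a core lacking the fluorine and gives 15800 nM. These two values lie within the scatter of each other, so both point to the same range in this assay.

No change beyond the scatter is therefore expected, and the expected step is an at least 1.2-fold lower number from compound 3 to compound 4 (0.10 log units; that floor lies within the scatter). For compound 4 the estimated value is 11000 nM, with an expected range of 4500 nM to 26000 nM.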

Compound 4, half-maximal inhibitory concentration: 20000 nM
The estimate for compound 4 lay 1.8-fold (0.26 log units) below the measured number, and the stated range covers the measured number.
By their numbers in this assay, from the lowest: compounds 2, 1 and 4 (each within the scatter of the next, the first and the last beyond it).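

In this assay, cyano in place of hydrogen now has a step that can be read and lies beyond the scatter, which the earlier limit could not provide: a 2.5-fold higher number from compound 2 to compound 4 (0.39 log units; beyond the scatter). Fluoro in place of hydrogen on the core does not separate the two 4-cyanophenyl compounds: a 1.3-fold higher number from compound 1 to compound 4 (0.10 log units; within the scatter). Compound 3 gives a limit and not a number, so the comparison of 2-cyanophenyl with 4-cyanophenyl on the aromatic nitrogen cannot be read: the limit of > 13900 nM in this assay, at which 1 of the 4 values shown sits.

From the compounds shown here alone, whether the two cyanophenyl groups differ at all in this assay remains open. Also open, going by these compounds, is how an amine, a carboxylic acid or a methoxy group in place of the nitrile on this phenyl ring would compare with compound 2 at 8120 nM.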